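Methanesulfonamido for fluoro on the pendant aryl ring

The source may hold more compounds than are shown below. What is called first, only, known or untested is meant among the compounds shown, and "the series" means these compounds.

Series notes on an in vitro functional assay on HEK285-7 cells for antagonist activity at prostaglandin D2 receptor 2 (Homo sapiens), read by BRET and beta-arrestin recruitment; on this read-out lower numbers stand for stronger inhibition and higher numbers for weaker inhibition. Compound 1 `O=C(O)Cc1sc(C(c2ccccc2)c2ccc(Cl)cc2)nc1-c1ccc(F)cc1` gives 79 nM, and compound 2 `O=C(O)Cc1sc(C(c2ccccc2)c2ccc(F)c(F)c2)nc1-c1ccc(F)cc1` gives 64 nM; the single-point step between them is a 1.2-fold lower number from compound 1 to compound 2 (0.09 log units; within the scatter). Compound 3 `O=C(O)Cc1sc(C(c2ccc(F)cc2)c2ccc(F)cc2)nc1-c1cccc(F)c1` gives 18 nM, the lowest of the three numbers, beyond the scatter from both compound 2 and compound 1. Compound 4 `CS(=O)(=O)Nc1cccc(-c2nc(C(c3ccc(F)cc3)c3ccc(F)cc3)sc2CC(=O)O)c1` differs from compound 3 by methanesulfonamido in place of fluoro on an aromatic carbon. Within the data shown here, no measured step touches this ring: the one step recorded concerns the saturated chain carbon bound to two aromatic carbons and stays within the scatter, so it gives no guidance on size or direction here. Compound 4 is therefore expected to sit near compound 3. The estimated step is a 1.1-fold higher number from compound 3 to compound 4 (0.05 log units; within the scatter), not beyond the scatter. For compound 4 the estimate is 20 nM, with a range from 6 nM to 60 nM.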

Compound 4, half-maximal inhibitory concentration: 370 nM
For compound 4 the middle estimate is 19-fold (1.27 log units) below the measured one; the whole stated range lies below it.
By their numbers in this assay, from the lowest: compound 3; then compounds 2 and 1 (each within the scatter of the next); then compound 4.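

In this assay this pendant aryl position proves sensitive to the change: methanesulfonamido in place of fluoro gives a 21-fold higher number from compound 3 to compound 4 (1.31 log units; beyond the scatter) and costs much of the inhibition seen with compound 3. The only earlier step concerned the saturated chain carbon and stayed within the scatter, so this is the first listed single-place step to show that the series can respond strongly to a substituent change. Nothing available accounts for the size of this step. From the compounds shown here alone, whether an acetamido or methylsulfonyl group at this place gives a similar step remains open, as does the outcome for a primary amine.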